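Swapping Pyrrole for Pyrazole on a Shared Imidazoline Core

The source may hold more compounds than are shown below. What is called first, only, known or untested is meant among the compounds shown, and "the series" means these compounds.

Measured compounds:
compound 1, `c1cnc(-c2ccccc2OCC2=NCCN2)nc1`: 90%
compound 2, `c1csc(-c2ccccc2OCC2=NCCN2)c1`: 101%
compound 3, `c1c[nH]c(-c2ccccc2OCC2=NCCN2)c1`: 99%

Three compounds share one core and differ only in the five-membered or six-membered ring attached to it. In a functional assay with Alpha-1A adrenergic receptor (Homo sapiens) as the target, read by calcium flux (on this read-out lower numbers stand for smaller maximal responses and higher numbers for larger maximal responses), compound 1 gives 90%, compound 2 gives 101%, and compound 3 gives 99%. Compound 3 thus stands second highest of the three numbers, but its neighbours are close: a number 2 percentage points lower from compound 2 to compound 3 (within the scatter), and a number 9 percentage points higher from compound 1 to compound 3 (within the scatter). Among the measured compounds shown here, only one step separates two compounds clearly, namely a number 11 percentage points higher from compound 1 to compound 2 (beyond the scatter).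

Compound 4, `c1ccc(-c2cc[nH]n2)c(OCC2=NCCN2)c1`, has not yet been measured in this assay. Compared with compound 3 the change is 1H-pyrazol-3-yl in place of 1H-pyrrol-2-yl on an aromatic carbon. For the measured compounds named here, the steps that bear on this are the two exchanges of one five-membered ring for another or for the six-membered ring in compound 1; both of those landed within the scatter, and even the largest step in the set was modest. For compound 4 the expected change is therefore a number 4 percentage points lower from compound 3 to compound 4 (within the scatter), a step that is not expected to exceed the scatter in this assay. Compound 4 is estimated to give 95%, with a likely range from 80% to 108%.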

Compound 4, largest response reached (reported as maximum), in percent of the reference or control that the assay uses: 119%
Compound 4: the middle estimate sits 24 percentage points below what was measured; measured number outside the range, above it.
By their numbers in this assay, from the lowest: compounds 1, 3 and 2 (each within the scatter of the next, the first and the last beyond it); then compound 4.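

In this assay, among the compounds shown here, the ring on this aromatic carbon, ortho to a group of 7 heavy atoms, matters more than the earlier compounds suggested: among them only one step went beyond the scatter, whereas 1H-pyrazol-3-yl stands clear of all three, with a number 20 percentage points higher from compound 3 to compound 4 (beyond the scatter), a number 18 percentage points higher from compound 2 to compound 4 (beyond the scatter) and a number 29 percentage points higher from compound 1 to compound 4 (beyond the scatter). Compound 4 therefore has the highest number of the set, and the change from compound 3 that goes with this is small on paper: the ring stays five-membered and aromatic with the same heavy-atom count and hydrogen-bond donor count, while one carbon gives way to a nitrogen and a hydrogen-bond acceptor is gained. Nothing available explains why this exchange raises the maximal response.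

Still open, as far as these compounds go, is whether the higher number survives with a methyl group on the pyrazole ring nitrogen, or with a 1H-imidazol-2-yl ring in its place. From the compounds shown here alone, the read-out also gives only the largest response reached, so how much of compound 4 is needed to reach that response remains unknown.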